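The source may report more compounds than this note shows. Statements on the series, on what has been measured and on what is new or still open speak of the compounds shown alone.

Three members of this series have so far been tested in a functional assay on HL-60 cells (Homo sapiens) for cytotoxicity, read by luminescence; on this read-out lower numbers stand for stronger inhibition and higher numbers for weaker inhibition. Compound 1 `C=C(CC)C(=O)c1ccc(OCC(=O)NCCNS(=O)(=O)C2CCCCC2)c(Cl)c1Cl` gives 1340 nM in this assay. Compound 2 `C=C(CC)C(=O)c1ccc(OCC(=O)NCCNS(C)(=O)=O)c(Cl)c1Cl` carries the change methyl in place of cyclohexyl on a sulfonyl sulfur relative to compound 1, and in this assay compound 2 gives 940 nM; the step of a 1.4-fold lower number from compound 1 to compound 2 (0.15 log units; within the scatter) stays within the scatter. Compound 3 `C=C(CC)C(=O)c1ccc(OCC(=O)N2CCN(S(=O)(=O)C3CCCCC3)CC2)c(Cl)c1Cl` is built on a different core, and the difference between the two cores is not broken down here. In this assay compound 3 gives 2320 nM.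

Compound 4 `C=C(CC)C(=O)c1ccc(OCC(=O)N2CCN(S(C)(=O)=O)CC2)c(Cl)c1Cl` has not yet been measured. It differs from compound 3 by methyl in place of cyclohexyl on a sulfonyl sulfur. This is the same kind of change as that between compound 1 and compound 2, though the surroundings differ: in compound 1 the sulfonyl sulfur's other neighbour is a sulfonamide nitrogen, whereas in compound 3 it is a sulfonamide nitrogen in a ring. Because the step of a 1.4-fold lower number from compound 1 to compound 2 (0.15 log units; within the scatter) stayed within the scatter, a step of similar size is expected here, a 1.4-fold lower number from compound 3 to compound 4 (0.15 log units; within the scatter). Compound 4 is therefore expected to give about 1650 nM in this assay, most likely between 850 nM and 3300 nM.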

Compound 4, half-maximal inhibitory concentration: 3390 nM
Estimate against measurement, compound 4: 2.1-fold (0.31 log units) below, and the stated range ends below it.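

In this assay, methyl in place of cyclohexyl on a sulfonyl sulfur whose other neighbour is a sulfonamide nitrogen in a ring gives a 1.5-fold higher number from compound 3 to compound 4 (0.16 log units; within the scatter). Compared with the same change on the other core, the two steps cannot be told apart: the same change on two cores in this assay, a 1.4-fold lower number (0.15 log units; within the scatter) from compound 1 to compound 2 and a 1.5-fold higher number (0.16 log units; within the scatter) from compound 3 to compound 4, 2.1-fold (0.32 log units) apart, within the scatter of two such steps. This shows that, in these two pairs, the change carries from one core to the other as a step too small to read, but it does not show that the two cores respond identically, nor does it give the change a direction on either core, and two pairs say nothing about other cores in this series.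

The compounds shown leave open whether a different group on the sulfonyl sulfur, such as a phenyl ring, a longer chain like butyl or a chain ending in an amine, would move the number beyond the scatter on either core. They also leave open whether the same holds in any read-out other than this assay.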